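Methoxy in Place of Chloro: Expected Shift in Cytotoxicity

The source may report more compounds than this note shows. Statements on the series, on what has been measured and on what is new or still open speak of the compounds shown alone.

Measured compounds:
compound 1, `COc1cccc(-c2cc(C(=O)Nc3ccc(Oc4ccnc5cc(OCCCN6CCCCC6)c(OC)cc45)c(F)c3)c3cc(F)ccc3n2)c1`, 1000 nM
compound 2, `COc1cc2c(Oc3ccc(NC(=O)c4cc(-c5cccc(Cl)c5)nc5ccc(F)cc45)cc3F)ccnc2cc1OCCCN1CCC(C)CC1`, 60 nM

Both numbers come from a functional assay on NCI-H460 cells (Homo sapiens) for cytotoxicity, read by MTT assay, with a stated time of 72 h; a higher number here means a weaker inhibitor, a lower number a stronger inhibitor. Of the two compounds measured, compound 2 gives the lowest number, 60 nM. Among the measured compounds shown here, its only neighbour, compound 1, gives a clearly higher number, a gap well beyond the usual scatter of this assay.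

Compound 3, `COc1cccc(-c2cc(C(=O)Nc3ccc(Oc4ccnc5cc(OCCCN6CCC(C)CC6)c(OC)cc45)c(F)c3)c3cc(F)ccc3n2)c1`, has not yet been measured. It differs from compound 2 in one place: methoxy in place of chloro on an aromatic carbon. For the measured compounds named here, no measured pair isolates this single change, so the expectation rests on the two values shown. Compound 1, which also bears the 3-methoxyphenyl, gives 1000 nM. It is not a clean comparison: it differs from compound 2 in more than this one place.

The step from compound 2 to compound 3 is expected to be a 5.0-fold higher number from compound 2 to compound 3 (0.70 log units; beyond the scatter), a weakening beyond the scatter. Compound 3 is therefore estimated at 300 nM, with a range from 80 nM to 1200 nM.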

Compound 3, half-maximal inhibitory concentration: 840 nM
Estimate against measurement, compound 3: 2.8-fold (0.45 log units) below; measured number inside the range.
By their numbers in this assay, from the lowest: compound 2; then compounds 3 and 1 (each within the scatter of the next).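

In this assay, the change from 3-chlorophenyl to 3-methoxyphenyl can now be read on its own, and it is a large loss (a 14-fold higher number from compound 2 to compound 3 (1.15 log units; beyond the scatter)). With the 3-methoxyphenyl in place, adding a methyl on a saturated ring carbon shows no effect beyond the scatter (a 1.2-fold lower number from compound 1 to compound 3 (0.08 log units; within the scatter)), so among these steps only the group on the aromatic ring makes a clear difference. No measurement at hand explains why the methoxy step is so large.

As far as these compounds go, it remains open whether an amine, a hydroxyl or a nitrile at this place on the aromatic ring would stay close to compound 2 or fall toward compound 3. From the compounds shown here alone, whether the methyl is just as silent with the 3-chlorophenyl in place also remains open.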